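The source may hold more compounds than are shown below. What is called first, only, known or untested is meant among the compounds shown, and "the series" means these compounds.

Compound 1 `O=C(CCCCCNC(=S)NN=C(c1ccccn1)c1ccccn1)NO`: 2870 nM
Compound 2 `O=C(CCCCCNC(=S)NN=C(c1ccccc1)c1ccccc1)NO`: 3810 nM

These values come from a functional assay on K562 cells (Homo sapiens) for antiproliferative activity, read by MTT assay; a higher number here means a weaker inhibitor, a lower number a stronger inhibitor. Compound 2 cannot be told apart from compound 1 on these numbers, since the two lie within the scatter of each other. Compound 3 `O=C(CCCCCNC(=S)N/N=C(\c1ccccc1)c1ccccc1F)NO` has not yet been measured. It carries a single change from compound 2: fluoro in place of hydrogen on an aromatic carbon.

Among the compounds with values here, no measured pair shows this change on its own. Within the data shown here, the only guide is that compound 1, at 2870 nM, stays within the scatter of compound 2, at 3810 nM, although the two differ by more than one atom. No step beyond the scatter is therefore expected in this assay, and the expected 1.2-fold lower number from compound 2 to compound 3 (0.08 log units; within the scatter) is small. The estimate for compound 3 is 3200 nM, within a range of 1600 nM to 6200 nM.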

Compound 3, half-maximal inhibitory concentration: 4630 nM
Estimate against measurement, compound 3: 1.4-fold (0.16 log units) below; low and high end bracket the measured number.
By their numbers in this assay, from the lowest: compounds 1, 2 and 3 (each within the scatter of the next).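

In this assay, within the data shown here, the change of hydrogen to fluoro on an aromatic carbon, ortho to a large group, gives the first single-change step in this set (a 1.2-fold higher number from compound 2 to compound 3 (0.08 log units; within the scatter)). Compound 2 and compound 3 therefore cannot be told apart, so at this position the fluoro group leaves the antiproliferative read-out without a detectable step, whereas the earlier comparison of compound 1 with compound 2 involved more than one change. Nothing available explains this outcome.

As far as these compounds go, whether chloro, methoxy or an amine on this same aromatic carbon would give a step beyond the scatter remains open. Among these compounds, it is also open whether a longer chain in place of the one shared by these compounds would separate them in this cell assay.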